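Sulfanyl substituents on the shared core and cell inhibition

The source may hold more compounds than are shown below. What is called first, only, known or untested is meant among the compounds shown, and "the series" means these compounds.

Compound 1 `Cc1cc(N2CC[C@@H](C)[C@@H](N(C)c3ncnc4[nH]ccc34)C2)n2ncnc2n1`: 4350 nM
Compound 2 `Cc1cc(N2CC[C@@H](C)[C@@H](N(C)c3ncnc4[nH]ccc34)C2)n2nc(SCCc3ccccc3)nc2n1`: 6190 nM
Compound 3 `Cc1cc(N2CC[C@@H](C)[C@@H](N(C)c3ncnc4[nH]ccc34)C2)n2nc(SCC3CCCCC3)nc2n1`: 9170 nM

In a functional assay on MGC-803 cells (Homo sapiens) for inhibition, read by MTT assay, with a stated time of 72 h (on this read-out lower numbers stand for stronger inhibition and higher numbers for weaker inhibition), compound 1 gives the lowest of the three numbers; compound 2 sits closest to it, compound 3 furthest. Both measured steps attach a sulfanyl group to the same aromatic carbon: a 1.4-fold higher number from compound 1 to compound 2 (0.15 log units; within the scatter) and a 2.1-fold higher number from compound 1 to compound 3 (0.32 log units; beyond the scatter); swapping the chain end, a 1.5-fold higher number from compound 2 to compound 3 (0.17 log units; within the scatter). Compound 4 `Cc1cc(N2CC[C@@H](C)[C@@H](N(C)c3ncnc4[nH]ccc34)C2)n2nc(SCc3ccc(Br)cc3)nc2n1` differs from compound 1 in that ((4-bromobenzyl)sulfanyl in place of hydrogen on an aromatic carbon). The two steps from compound 1 are the ones that bear on it, and they point the same way, so a similar small rise in this assay is expected: a 1.5-fold higher number from compound 1 to compound 4 (0.17 log units; within the scatter). Compound 4 is therefore estimated at 6500 nM, with a range of 3500 nM to 12000 nM.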

Compound 4, half-maximal inhibitory concentration: 4020 nM
Compound 4: middle estimate off by 1.6-fold (0.21 log units), on the high side, within the range that was stated.
By their numbers in this assay, from the lowest: compounds 4, 1, 2 and 3 (each within the scatter of the next, the first and the last beyond it).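

In this assay the (4-bromobenzyl)sulfanyl group, on the aromatic carbon between two ring nitrogen atoms, leaves the number level with the hydrogen of the shared core (a 1.1-fold lower number from compound 1 to compound 4 (0.03 log units; within the scatter)). The chain end still matters modestly: the gap to the cyclohexylmethyl compound lies beyond the scatter (a 2.3-fold lower number from compound 3 to compound 4 (0.36 log units; beyond the scatter)), while the gap to the phenethyl compound stays within it (a 1.5-fold lower number from compound 2 to compound 4 (0.19 log units; within the scatter)). No measured evidence accounts for these differences. As far as these compounds go, whether a terminal amine or carboxylic acid, or a longer chain, would move the number clearly away from compound 1 remains open.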